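A few compounds are considered here, and "the series" means these few. Any claim that something is new, unique, unknown or untested is made for them only; others in the source may bear on it.

In an assay on HEK293 cells for inhibition of Ataxin-2 (Mus musculus), read by fluorescence and Amplex Red (on this read-out higher numbers stand for weaker inhibition and lower numbers for stronger inhibition), two compounds have been measured. Compound 1 `NS(=O)(=O)c1ccc(COc2ccc(CNC(=O)[C@@H]3CCC(=O)N3Cc3ccc(F)cc3)cc2)cc1` returns only a limit of the assay, > 5000 nM. Compound 2 `O=C(NCc1ccc(OCc2ccc(-c3nn[nH]n3)cc2)cc1)[C@@H]1CCC(=O)N1Cc1ccccc1`, which carries a plain benzyl group, likewise returns only a limit in this assay, > 5000 nM. Compound 2 thus stands at the limit of > 5000 nM in this assay, at which 2 of the 2 values shown sit, so no number is known for it, only that it lies past the edge of the measurable range.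

The step to compound 3 `O=C(NCc1ccc(OCc2ccc(-c3nn[nH]n3)cc2)cc1)[C@@H]1CCC(=O)N1Cc1ccc(F)cc1` is fluoro in place of hydrogen on an aromatic carbon; one bond further out, this reads benzyl to 4-fluorobenzyl. Within the data shown here, no measured step between compounds accompanies this change. With compound 2 reported only as a limit at > 5000 nM, the step the estimate implies, a step that the limit leaves unreadable from compound 2 to compound 3, is expected to be none beyond the scatter. Compound 3 is therefore expected at about 10000 nM, within a range from 4000 nM to 30000 nM, and most probably reported again only as a limit.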

Compound 3, half-maximal inhibitory concentration: > 5000 nM
Compound 3 was reported as a limit; the forecaster's own chance of this, stated with the estimate: 85%; the middle value lies beyond the limit too.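

No step can be read for compound 3 against compound 1 or compound 2 in this assay, because compound 1, compound 2 and compound 3 are all reported only as limits: the limit of > 5000 nM in this assay, at which 3 of the 3 values shown sit. The compounds shown leave open whether fluoro in place of hydrogen, or 2H-tetrazol-5-yl in place of sulfamoyl, changes inhibition at all.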